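Moving the Ring Nitrogen in a Urea Series

A few compounds are considered here, and "the series" means these few. Any claim that something is new, unique, unknown or untested is made for them only; others in the source may bear on it.

Compound 1, `O=C(Nc1ccc(F)c(C(F)(F)F)c1)Nc1ccccn1`, gives 705 uL/min in an ADME assay on microsomes from liver (Mus musculus) for metabolic stability, using NADPH, with a stated time of 60 min; a higher number here means faster removal of the compound, a lower number slower removal.
Compound 3, `CC(=O)c1ccc(NC(=O)Nc2ccc(F)c(C(F)(F)F)c2)cc1`, gives 14 uL/min in this assay.
Compound 2, `O=C(Nc1cccc(C(=O)O)c1)Nc1ccc(F)c(C(F)(F)F)c1`, reaches only < 7 uL/min in this assay, which is a limit of the assay and not a number (the limit of < 7 uL/min in this assay, at which 1 of the 3 values shown sits).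

Among the two numbers shown, compound 1 stands highest, so it is the compound removed fastest; its nearest neighbour is compound 3, which lies far below it, well beyond the usual scatter. Compound 4, `O=C(Nc1cccnc1)Nc1ccc(F)c(C(F)(F)F)c1`, keeps every atom of compound 1 but joins them differently: pyridin-3-yl in place of pyridin-2-yl on an amide-type nitrogen. For the measured compounds named here, no measured pair in this set shares that change; compounds 2 and 3 differ from compound 1 elsewhere, at the other aryl ring, so they give no guide to the size of this step. The shift of one ring nitrogen is expected to be modest, and is estimated as a small drop in the clearance number, close to the edge of the scatter, as a 2.0-fold lower number from compound 1 to compound 4 (0.30 log units; within the scatter). Compound 4 is therefore expected to give about 350 uL/min in this assay, with a likely range from 120 uL/min to 1000 uL/min.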

Compound 4, intrinsic clearance in a liver preparation (reported as CLH), per the amount of preparation that the assay uses: 154 uL/min
Compound 4: middle estimate off by 2.3-fold (0.36 log units), on the high side, within the range that was stated.
By their numbers in this assay, from the lowest: compound 3; then compound 4; then compound 1. At a limit, below all of these: compound 2.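

The ring nitrogen alone is enough to change the result: with the same atoms joined differently, pyridin-3-yl in place of pyridin-2-yl on an amide-type nitrogen gives a 4.6-fold lower number from compound 1 to compound 4 (0.66 log units; beyond the scatter) in this assay. This place on the shared core therefore responds to a change that adds and removes no atoms, which compound 2 and compound 3 could not show, as both differ from compound 1 at the other aryl ring. Nothing measured here explains why moving the ring nitrogen has this effect.

On these data alone, it remains open whether pyridin-4-yl or an unsubstituted phenyl ring on the same nitrogen would give a higher or lower number than pyridin-3-yl. Also open, as far as these compounds go, is whether a methoxy group on the pyridin-3-yl ring would change the number further.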